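Ester variation on the oxamide series: phenyl for tert-butyl

The source may report more compounds than this note shows. Statements on the series, on what has been measured and on what is new or still open speak of the compounds shown alone.

Compound 3 `CC(C)(C)OC(=O)C(=O)Nc1cccccc1=O` is the tert-butyl ester of the series. In a functional assay on the whole organism (strain Sprague-Dawley CD) for inhibition, with Rattus norvegicus as the target, read by paw edema, at a dose of 30 mg/kg by the intraperitoneal route (on this read-out lower numbers stand for a weaker effect and higher numbers for a stronger effect at the one dose given), compound 3 gives 79%, the highest of the three numbers measured. Compound 2 `CCOC(=O)C(=O)Nc1ccccc(-c2ccccc2)c1=O` gives 72% in this assay, and the two values lie within the scatter of each other, so no order between compound 3 and compound 2 can be read. Compound 1 `CCOC(=O)C(=O)Nc1ccccc(C)c1=O` gives 60% in this assay, a number beyond the scatter below that of compound 3.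

Compound 4 `O=C(Nc1cccccc1=O)C(=O)Oc1ccccc1` differs from compound 3 in one place: phenyl in place of tert-butyl on an oxygen next to a carbonyl group. Within the data shown here, the only measured step in the set is a number 12 percentage points higher from compound 1 to compound 2 (beyond the scatter). That step also brings in a phenyl, but on an aromatic carbon rather than on the ester oxygen, so it bears on the present change only loosely. Among the measured compounds shown here, no measured step varies the ester group itself, and the spread between the tert-butyl ester of compound 3 and the ethyl ester of compound 1 is confounded by the change on the ring. The expectation for compound 4 in this assay is therefore a step of a number 4 percentage points lower from compound 3 to compound 4 (within the scatter), not beyond the scatter in either direction. Compound 4 is estimated at 75%, within a range of 60% to 90%.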

Compound 4, a percentage reported as inhibition, in the whole organism at one dose (the size of the read-out at that dose, not a potency): 73%
For compound 4 the middle estimate is 2 percentage points above the measured one, within the range that was stated.
By their numbers in this assay, from the lowest: compound 1; then compounds 2, 4 and 3 (each within the scatter of the next).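

Among these compounds, this is the first measured step that varies the ester group alone: in this assay the result is a number 6 percentage points lower from compound 3 to compound 4 (within the scatter). At this one dose, then, the ester oxygen carries either tert-butyl, with no ring, or phenyl, with one six-membered aromatic ring, and the read-out does not separate the two, so an aromatic ring in this place does not cost a measurable part of the effect. Among the compounds shown here, the earlier compounds could not show this, as their only measured step sits on an aromatic carbon and their esters differ alongside a change on the ring; no supporting data bear on the reason for the present result.

Open, as far as these compounds go, is how the core of compound 3 would read with a carboxylic acid, a benzyl ester or a simple ethyl ester at this place, any of which would show whether the insensitivity extends beyond these two groups. Also open, from the compounds shown here alone, is whether compound 3 and compound 4 would separate at other doses, as a single-dose read-out gives the size of the effect and not a potency.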